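From bromo to azido on a shared core

The source may hold more compounds than are shown below. What is called first, only, known or untested is meant among the compounds shown, and "the series" means these compounds.

Among the measured compounds shown here, in a functional assay on L1210 cells (Mus musculus) for inhibition (on this read-out lower numbers stand for stronger inhibition and higher numbers for weaker inhibition), compound 1 `CS(=O)(=O)OC[C@H]1OC(n2cc(F)c(=O)[nH]c2=O)[C@H](O)[C@@H]1O` gives 320 nM, while compound 2 `O=c1[nH]c(=O)n(C2O[C@H](CBr)[C@@H](O)[C@H]2O)cc1F` gives 800 nM, the higher of the two numbers so far. Compound 3 `[N-]=[N+]=NC[C@H]1OC(n2cc(F)c(=O)[nH]c2=O)[C@H](O)[C@@H]1O` carries azido in place of bromo on a saturated chain carbon bound to a saturated ring carbon. For the measured compounds named here, only one measured step bears on this place, the modest 2.5-fold higher number from compound 1 to compound 2 (0.40 log units; beyond the scatter). It suggests that swapping this group moves this assay only a little, so no step beyond the scatter is expected. The expected step is a 1.3-fold lower number from compound 2 to compound 3 (0.12 log units; within the scatter). For compound 3 the estimated value is 600 nM, with an expected range of 200 nM to 1800 nM.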

Compound 3, half-maximal inhibitory concentration: 170000 nM
The estimate for compound 3 lay 280-fold (2.45 log units) below the measured number; the whole stated range lies below it.
By their numbers in this assay, from the lowest: compound 1; then compound 2; then compound 3.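

In this assay, this position proves far more sensitive than the earlier pair suggested: putting azido in place of bromo gives a much weaker result (a 210-fold higher number from compound 2 to compound 3 (2.33 log units; beyond the scatter)), and putting it in place of (methylsulfonyl)oxy gives a still larger step (a 530-fold higher number from compound 1 to compound 3 (2.73 log units; beyond the scatter)). The group on this saturated chain carbon can therefore decide nearly all of the inhibition seen here, and the earlier step looks small beside these. No measurement shown here explains the loss. On these data alone, whether it is particular to azido remains open, and an amine or an iodo group on this same carbon would help to show that.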